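This account rests on a few compounds, and the source may have more. Where it says the series, first, only, none or still open, it means among the compounds named here.

Compounds measured in a functional assay on HCC827 cells (Homo sapiens) for antiproliferative activity, read by MTT assay, with a stated time of 72 h; on this read-out higher numbers stand for weaker inhibition and lower numbers for stronger inhibition:
Compound 1 `CN1CCN(c2ccc(Nc3ncc4nc(SCc5cccnc5)n(C5CCCC5)c4n3)cc2)CC1`: 517 nM
Compound 2 `CN1CCN(c2ccc(Nc3ncc4nc(SCc5cccnc5)n(C5CC5)c4n3)cc2)CC1`: 8830 nM

Compound 2 holds the higher of the two numbers, and the pair shows a 17-fold higher number from compound 1 to compound 2 (1.23 log units; beyond the scatter), with cyclopropyl in place of cyclopentyl on an aromatic nitrogen. Compound 3 `CN1CCN(c2ccc(Nc3ncc4nc([S+]([O-])c5ccccc5)n(C5CC5)c4n3)cc2)CC1` keeps the cyclopropyl group and changes elsewhere: a group of 8 heavy atoms (6 carbon, 1 oxygen, 1 sulfur; one six-membered aromatic ring of carbon only) in place of a group of 8 heavy atoms (6 carbon, 1 nitrogen, 1 sulfur; one six-membered aromatic ring with 1 hetero atom), on an aromatic carbon. The new group sits on an aromatic carbon between two ring nitrogen atoms. Among the compounds with values here, no measured step covers this exchange. Within the data shown here, the one available step, a 17-fold higher number from compound 1 to compound 2 (1.23 log units; beyond the scatter), lies at another place and shows only that a single change there moved the number far. Since compound 2 stands at 8830 nM, the higher end of what has been seen, a moderate move towards a lower number in this assay is expected, with little confidence. The expected change is a 1.8-fold lower number from compound 2 to compound 3 (0.25 log units; within the scatter). The estimated value for compound 3 is 5000 nM, within a range of 1200 nM to 20000 nM.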

Compound 3, half-maximal inhibitory concentration: 1630 nM
Estimate against measurement, compound 3: 3.1-fold (0.49 log units) above, and the stated range covers the measured number.
By their numbers in this assay, from the lowest: compound 1; then compound 3; then compound 2.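

At the aromatic carbon between two ring nitrogen atoms, with the cyclopropyl group held fixed, the exchange gives a 5.4-fold lower number from compound 2 to compound 3 (0.73 log units; beyond the scatter) in this assay, so the number responds at this place as well as on the aromatic nitrogen. The leaving ((pyridin-3-yl)methyl)sulfanyl group and the group that enters have the same count of heavy atoms, so that count alone does not set the number here. No measurement is available that explains this step.

As far as these compounds go, it remains open which part of the exchange carries the step, the oxygen, the ring of carbon only or the loss of the ring nitrogen, and whether it would hold with cyclopentyl on the aromatic nitrogen. From the compounds shown here alone, how an amine or a carboxylic acid on the aromatic ring would read also remains open.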